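Swapping the Aryl Group on a Triazole-Bearing Scaffold

The source may hold more compounds than are shown below. What is called first, only, known or untested is meant among the compounds shown, and "the series" means these compounds.

Compound 1 `C=C1C(=O)[C@]23C[C@@]1(O)CC[C@H]2c1ccc(O)c(C)c1[C@@H]3Cn1cc(-c2ccc(C(F)(F)F)cc2)nn1`: 370 nM
Compound 2 `C=C1C[C@]23C[C@@]1(O)CC[C@@H]2c1cccc(C)c1[C@@H]3Cn1cc(-c2ccc(F)cc2)nn1`: > 20000 nM
Compound 3 `Cc1ccc(-c2cn(C[C@H]3c4c(ccc(OS(=O)(=O)c5ccc(C)cc5)c4C)[C@@H]4CC[C@@]5(C)C[C@]43CC5=O)nn2)cc1`: > 20000 nM

Among the compounds with values here, in a functional assay on SW480 cells (Homo sapiens) for cytotoxicity, read by MTT assay, with a stated time of 4 days (on this read-out lower numbers stand for stronger inhibition and higher numbers for weaker inhibition), compound 1 gives 370 nM, the only numerical value among the three measured compounds. For compound 2 this assay reports only a limit, > 20000 nM. For compound 3 likewise only a limit is reported, > 20000 nM. Compound 1 therefore stands alone with a number, while the other two sit at the limit of > 20000 nM in this assay, at which 2 of the 3 values shown sit. Within the data shown here, no two of the measured compounds differ in a single place, so no measured step can be stated; compound 2 and compound 3 show only that at the limit no inhibition was picked up.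

Compound 4 `C=C1C(=O)[C@]23C[C@@]1(O)CC[C@H]2c1ccc(O)c(C)c1[C@@H]3Cn1cc(-c2ccccn2)nn1` is the compound still to be measured. It keeps the shared core of compound 1 and differs from it in one place: pyridin-2-yl in place of 4-(trifluoromethyl)phenyl on an aromatic carbon. Among the measured compounds shown here, with no measured step of this kind to draw on, the expected change is a modest loss of potency, and the step from compound 1 to compound 4 that this expectation means is a 4.1-fold higher number from compound 1 to compound 4 (0.61 log units; beyond the scatter), larger than the usual scatter but not a collapse to the limit. For compound 4 the value expected in this assay is 1500 nM, with a plausible range from 400 nM to 6000 nM.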

Compound 4, half-maximal inhibitory concentration: 410 nM
For compound 4 the middle estimate is 3.7-fold (0.56 log units) above the measured one, and the stated range covers the measured number.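

Within the data shown here, this is the first step that can be read at this position, the aromatic carbon of the five-membered aromatic ring with 3 nitrogen: in this assay, pyridin-2-yl in place of 4-(trifluoromethyl)phenyl gives a 1.1-fold higher number from compound 1 to compound 4 (0.04 log units; within the scatter). The two compounds therefore cannot be told apart on this read-out, even though the entering group has fewer heavy atoms than the leaving group, carries no fluorine, and brings 1 hydrogen-bond acceptor where the leaving group has 0. For this pair, the trifluoromethyl group and the carbon-only ring are not needed to keep the number where it stands in this assay, something compound 1 could not show by itself.

From the compounds shown here alone, a single pair cannot show how far this tolerance extends, so it remains open whether a plain phenyl ring, a morpholine or a carboxylic acid on the ring, or a longer chain in its place, would leave the number unchanged. Nothing measured here gives a reason for the outcome of this exchange.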